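The compounds below may be only part of what the source reports. "The series", "measured", "known", "first", "only" and "open" are said of these compounds alone.

Measured so far in an ADME assay on MT2 cells (Homo sapiens) for cytotoxicity; a lower number here means that less compound is tolerated, a higher number that more compound is tolerated:
Compound 1 `CC1(C)OC(=O)C2(C(=O)O1)[C@@H](c1ccco1)CC(=O)C[C@H]2c1ccco1`: a limit only, > 111000 nM
Compound 2 `CC1(C)OC(=O)C2(C(=O)O1)[C@@H](c1ccco1)CC(=O)C[C@H]2c1ccc(Br)cc1`: a limit only, > 111000 nM
Compound 3 `CC1(C)OC(=O)C2(C(=O)O1)[C@@H](c1ccco1)CC(=O)C[C@H]2c1ccccc1Cl`: a limit only, > 111000 nM

Within the data shown here, compound 3 stands where every value of the series so far stands, namely at the limit of > 111000 nM in this assay, at which 3 of the 3 values shown sit; no number exists for it, only the limit. The change to compound 4 `COc1ccc([C@@H]2CC(=O)C[C@H](c3ccco3)C23C(=O)OC(C)(C)OC3=O)cc1OC` is 3,4-dimethoxyphenyl in place of 2-chlorophenyl on a saturated ring carbon. The measured steps that touch the same saturated ring carbon are a step that the two limits leave unreadable from compound 1 to compound 3, a step that the two limits leave unreadable from compound 2 to compound 3 and a step that the two limits leave unreadable from compound 1 to compound 2; none of them has a readable size, and none shows a direction. The series gives nothing to build a trend on, so the expectation in this assay is no step beyond the scatter, with compound 4 most likely reported once more as a limit rather than as a number. The estimate for compound 4 is 150000 nM, with a range from 111000 nM to 300000 nM. The expected step is a step that the limit leaves unreadable from compound 3 to compound 4.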

Compound 4, half-maximal cytotoxic concentration: > 111000 nM
Compound 4 gave a limit, no number; the forecaster's own chance of this, stated with the estimate: 85%; the middle value is on the limit's open side.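

In this assay compound 4 gives a limit and no number, so no step among compound 1, compound 2, compound 3 and compound 4 can be read, because all four share one limit: the limit of > 111000 nM in this assay, at which 4 of the 4 values shown sit.

The compounds shown leave open whether any group on this saturated ring carbon gives a measurable half-maximal cytotoxic concentration.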